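The compounds below may be only part of what the source reports. "The series", "measured", "known", "first", "only" and "open" are said of these compounds alone.

- Compound 1 `COc1ccc(CN(C(=O)CSc2nc3ccccc3s2)c2cc(OC)c(OC)c(OC)c2)cc1C`: 17100 nM
- Compound 2 `COc1ccc(CN(C(=O)CSc2nc3ccccc3s2)c2cc(OC)c(OC)c(OC)c2)cc1O`: 182 nM
- Compound 3 `COc1cc(N(Cc2ccc(F)cc2)C(=O)CSc2nc3ccccc3s2)cc(OC)c1OC`: 59800 nM

In a functional assay on HCT-116 cells (Homo sapiens) for antiproliferative activity, read by MTT assay, with a stated time of 48 h (on this read-out higher numbers stand for weaker inhibition and lower numbers for stronger inhibition), compound 3 gives 59800 nM, the highest number of the three and so the weakest inhibition measured here. Its gap to the other two differs greatly in size: a 3.5-fold higher number from compound 1 to compound 3 (0.54 log units; beyond the scatter), but a 330-fold higher number from compound 2 to compound 3 (2.52 log units; beyond the scatter).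

The next compound, compound 4 `COc1ccc(CN(C(=O)CSc2nc3ccccc3s2)c2cc(OC)c(OC)c(OC)c2)cc1C(F)(F)F`, has not yet been measured. It carries 4-methoxy-3-(trifluoromethyl)phenyl in place of 4-fluorophenyl on a saturated chain carbon bound to an amide-type nitrogen.

The nearest guide is compound 1, whose 4-methoxy-3-methylphenyl group has methyl where compound 4 has trifluoromethyl. Its step to compound 3 was modest, and that makes a similar modest gain plausible. The large step of a 94-fold lower number from compound 1 to compound 2 (1.97 log units; beyond the scatter) came with a hydroxy group, which compound 4 lacks, so a gain of that size seems unlikely. Among the measured compounds shown here, no measured compound carries trifluoromethyl, which leaves real uncertainty.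

A modest move towards stronger inhibition is therefore expected in this assay, an estimated 3.0-fold lower number from compound 3 to compound 4 (0.48 log units; beyond the scatter). For compound 4 the expected value is 20000 nM, with an estimated range from 5000 nM to 70000 nM.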

Compound 4, half-maximal inhibitory concentration: > 80000 nM
Compound 4: no number, only a limit; the forecaster's own chance of this, stated with the estimate: 10%; middle value at least 4.0-fold (0.60 log units) away from the limit.
By their numbers in this assay, from the lowest: compound 2; then compound 1; then compound 3. At a limit, above all of these: compound 4.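

Compound 4 gives only a limit in this assay, not a number: the limit of > 80000 nM in this assay, at which 1 of the 4 values shown sits.

This is the first look at trifluoromethyl on this aromatic carbon, and it does not improve on methyl: the change runs towards weaker inhibition, with an at least 4.6-fold higher number from compound 1 to compound 4 (0.67 log units; beyond the scatter), while replacing the hydroxy group gives an at least 430-fold higher number from compound 2 to compound 4 (2.64 log units; beyond the scatter), so among these four compounds, hydroxy remains the only group on this carbon tied to strong inhibition. The comparison with the 4-fluorophenyl compound is less clear, since an at least 1.3-fold higher number from compound 3 to compound 4 (0.12 log units; that floor lies within the scatter) cannot separate the two, and 4-methoxy-3-(trifluoromethyl)phenyl and 4-fluorophenyl may sit close together or far apart at the weak end of this series.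

The compounds shown leave open whether the gain belongs to hydroxy alone or would also come with an amine or a carboxylic acid on the same aromatic carbon. They also do not tell whether a chlorine atom or an ethyl group there would behave more like methyl or more like trifluoromethyl.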